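The compounds below may be only part of what the source reports. "The series", "measured", "known", "first", "only" and "open" are said of these compounds alone.

Three compounds of the series have numbers in a functional assay on the whole organism (Hindlimb, strain albino) with Mus musculus as the target, in the maximal electroshock model, with a stated time of 0.5 h; a lower number here means that less compound is needed, a higher number that more compound is needed for the effect. Compound 1 `CC(=O)N1N=C(Nc2nc3ccc(C)cc3s2)CC1c1ccc(O)cc1` gives 50.2 umol/kg in this assay. Compound 2 `CC(=O)N1N=C(Nc2nc3ccc([N+](=O)[O-])cc3s2)CC1c1ccc(O)cc1` carries the change nitro in place of methyl on an aromatic carbon and gives 162 umol/kg; the step of a 3.2-fold higher number from compound 1 to compound 2 (0.51 log units; beyond the scatter) is beyond the scatter. Compound 3 `Cc1ccc2nc(NC(=O)/C=C/c3ccc(Cl)cc3)sc2c1` has a different core from compound 1, and the difference between the two cores is not broken down here; in this assay compound 3 gives 152 umol/kg, which stands within the scatter of compound 2 and is a higher number than compound 1.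

Compound 4 `O=C(/C=C/c1ccc(Cl)cc1)Nc1nc2ccc([N+](=O)[O-])cc2s1` has not yet been measured. It differs from compound 3 by nitro in place of methyl on an aromatic carbon, the same change as the one from compound 1 to compound 2, since the two place lines match word for word; it occurs twice among the compounds shown. The expectation rests on compound 1 and compound 2, where the step was a 3.2-fold higher number from compound 1 to compound 2 (0.51 log units; beyond the scatter), and on compound 3 at 152 umol/kg. A step of about a 3.0-fold higher number from compound 3 to compound 4 (0.47 log units; beyond the scatter) is expected, assuming the change carries over to the second core. For compound 4 the estimate in this assay is 450 umol/kg, with a range from 200 umol/kg to 1000 umol/kg.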

Compound 4, dose for half-maximal effect: 259 umol/kg
Compound 4: the middle estimate sits 1.7-fold (0.24 log units) above what was measured, within the range that was stated.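

In this assay, nitro in place of methyl on an aromatic carbon gives a 1.7-fold higher number from compound 3 to compound 4 (0.23 log units; within the scatter) on the second core, so this step alone does not separate the two compounds. Set beside the earlier step, the two cores cannot be told apart for this change: the same change on two cores in this assay, a 3.2-fold higher number (0.51 log units; beyond the scatter) from compound 1 to compound 2 and a 1.7-fold higher number (0.23 log units; within the scatter) from compound 3 to compound 4, 1.9-fold (0.28 log units) apart, within the scatter of two such steps

Going by these compounds alone, both steps point towards a higher number, which fits a carry-over between the two cores, but this rests on only two pairs, and it does not show that the step has one fixed size or that it would hold on any further core.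

The compounds shown hold only methyl and nitro at this aromatic carbon, so it remains open whether an amine, a methoxy group or a longer alkyl chain there would follow the same course. No pair shown changes the core alone, so what each core itself contributes to the numbers also remains open.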